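Cytotoxicity notes on a boron-containing chalcone series

The source may report more compounds than this note shows. Statements on the series, on what has been measured and on what is new or still open speak of the compounds shown alone.

Compound 1 `O=C(/C=C/c1ccc2c(c1)B(O)OC2)c1ccccc1O`: in an ADME assay on L929 cells (Mus musculus) for cytotoxicity, read by resazurin assay, with a stated time of 72 h (a higher number here means a weaker inhibitor, a lower number a stronger inhibitor), compound 1 gives only a limit, > 10 ug/mL.
Compound 2 `O=C(/C=C/c1ccc2c(c1)B(O)OC2)c1ccc(O)cc1`: in this assay compound 2 gives only a limit, > 10 ug/mL.

For the measured compounds named here, compound 2 stands where every value so far sits, at the limit of > 10 ug/mL in this assay, at which 2 of the 2 values shown sit. Going by the values given here, the single measured step, a step that the two limits leave unreadable from compound 1 to compound 2, is unreadable, so no shift from moving the hydroxy about the ring can be read from it.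

Compound 3 `O=C(O)c1ccc(C(=O)/C=C/c2ccc3c(c2)B(O)OC3)cc1` differs from compound 2 by carboxy in place of hydroxy on an aromatic carbon. Among the compounds with values here, no measured step bears on a carboxy entering in place of a hydroxy; the only step known lies between two limits and gives no size. Compound 3 is therefore expected to remain at the same limit, with a step that the limit leaves unreadable from compound 2 to compound 3 that is expected to be nothing beyond the scatter, because both compound 1 and compound 2 sit at the limit of > 10 ug/mL in this assay, at which 2 of the 2 values shown sit. The estimate for compound 3 in this assay is 20 ug/mL, within 8 ug/mL to 60 ug/mL.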

Compound 3, half-maximal inhibitory concentration: > 10 ug/mL
Compound 3: only a limit was reported; the forecaster's own chance of this, stated with the estimate: 85%; the middle value is on the limit's open side.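

Compound 2 and compound 3 both give only a limit in this assay, so no step between them can be read: the limit of > 10 ug/mL in this assay, at which 3 of the 3 values shown sit.

The compounds shown leave open where the half-maximal inhibitory concentrations of compound 1, compound 2 and compound 3 actually lie, and whether carboxy in place of hydroxy shifts them at all.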